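Ethyl removal from the sulfur of compound 1

A few compounds are considered here, and "the series" means these few. Any claim that something is new, unique, unknown or untested is made for them only; others in the source may bear on it.

Among the compounds with values here, compound 1 `CCSc1nc(N)c2nc(O)n(Cc3ccccc3)c2n1` is the only member of the set with a number rather than a limit in a functional assay (spleen, spleen) for activation, with Mus musculus as the target; a lower number here means that less compound is needed, a higher number that more compound is needed for the effect: compound 1 gives 0.1 uM. Compound 2 `CSc1nc2c(N)ncnc2n1Cc1ccccc1` returns only a limit of the assay, > 10 uM. Compound 3 `Nc1ncnc2c1nc(O)n2C1CCCC1` likewise stops at a limit, > 10 uM. Within the data shown here, two of the three results thus sit at the limit of > 10 uM in this assay, at which 2 of the 3 values shown sit, so compound 1 stands alone as the one measurable point, and no step between measured compounds is available to calibrate the change below.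

Compound 4 `Nc1nc(S)nc2c1nc(O)n2Cc1ccccc1` is compound 1 with one alteration: hydrogen in place of ethyl on a sulfur. The ethyl leaves and a hydrogen enters on the sulfur whose other neighbour is an aromatic carbon, so the ethylsulfanyl group becomes a sulfanyl group; the rest of the shared core is kept.

Among the measured compounds shown here, with no measured step for guidance, the size of the change rests on expectation only. Loss of the ethyl is expected to cost potency clearly beyond the scatter, and a result that again ends at the assay limit cannot be excluded. For compound 4 the expected step is a 20-fold higher number from compound 1 to compound 4 (1.30 log units; beyond the scatter). Compound 4 is estimated at 2 uM, within 0.3 uM to 10 uM.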

Compound 4, minimum effective concentration: 10 uM
The estimate for compound 4 lay 5.0-fold (0.70 log units) below the measured number, and the stated range covers the measured number.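

In this assay, within the data shown here, hydrogen in place of ethyl on the sulfur gives a 100-fold higher number from compound 1 to compound 4 (2.00 log units; beyond the scatter), the first measured step, with the rest of the shared core kept. The ethyl on this sulfur therefore matters greatly to the read-out, although its loss does not abolish the effect: compound 4 still gives a number, 10 uM, and not a limit. That number nevertheless stands at the same figure as the limit reached by two other compounds, so little measurable range remains beneath it in this series: the limit of > 10 uM in this assay, at which 2 of the 4 values shown sit.

As far as these compounds go, with the rest of the core kept, only ethyl and hydrogen can be compared on this sulfur, so the effect of a longer chain such as propyl or butyl, of a benzyl group, or of an amine in place of the sulfanyl group remains open. A single step also cannot show whether the read-out follows chain length on the sulfur or whether ethyl is a special case.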